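A few compounds are considered here, and "the series" means these few. Any claim that something is new, unique, unknown or untested is made for them only; others in the source may bear on it.

Compound 2 `CC(C(=O)N1Cc2ccccc2C1)N1CCN(S(=O)(=O)c2ccc(C(C)(C)C)cc2)CC1` shares its core with compound 1 `CC(C(=O)N1CC2CC2C1)N1CCN(S(=O)(=O)c2ccc(C(C)(C)C)cc2)CC1`; the two differ only in the group attached to the carbonyl carbon. In an ADME assay on HepG2 cells (Homo sapiens) for inhibition, with a stated time of 48 h (on this read-out lower numbers stand for an effect already at smaller amounts and higher numbers for an effect only at larger amounts of compound), compound 2 gives only a limit of the assay, > 40000 nM. In this assay compound 1 likewise gives only a limit, > 40000 nM. Among the measured compounds shown here, the one measured step, a step that the two limits leave unreadable from compound 1 to compound 2, has no readable size because of the limit of > 40000 nM in this assay, at which 2 of the 2 values shown sit. Compound 3 `CC(C(=O)N1CCc2ncccc2C1)N1CCN(S(=O)(=O)c2ccc(C(C)(C)C)cc2)CC1` differs from compound 2 by a group of 10 heavy atoms (8 carbon, 2 nitrogen; one six-membered non-aromatic ring with 1 hetero atom, one six-membered aromatic ring with 1 hetero atom) in place of a group of 9 heavy atoms (8 carbon, 1 nitrogen; one five-membered non-aromatic ring with 1 hetero atom, one six-membered aromatic ring of carbon only), on a carbonyl carbon. For the measured compounds named here, no measured step with a readable size bears on this change; the only comparison at hand, between compound 1 and compound 2, shows two limits and nothing more. The expected step is therefore a number no higher from compound 2 to compound 3 (the limit leaves the size open), with the outcome most likely reported again as a limit rather than as a number. Compound 3 is expected at about 40000 nM, in the range 20000 nM to 80000 nM.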

Compound 3, half-maximal effective concentration: > 40000 nM
Compound 3 gave a limit, no number; the forecaster's own chance of this, stated with the estimate: 85%; the middle value sits exactly at the limit.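

The steps linking compound 3 to compound 1 and compound 2 cannot be read, and no new step comes from this result, for one reason: the limit of > 40000 nM in this assay, at which 3 of the 3 values shown sit.

The compounds shown leave open how the groups on the carbonyl carbon compare in this assay, since none gives a number.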